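Cytotoxicity Outlook for a Chloro-for-Fluoro Swap

A few compounds are considered here, and "the series" means these few. Any claim that something is new, unique, unknown or untested is made for them only; others in the source may bear on it.

Compound 3, `C[C@]1(CN2CCc3nc(-c4ccc(F)c(F)c4)ccc3C2)Cn2cc([N+](=O)[O-])nc2O1`, was tested in an ADME assay on Vero cells (Chlorocebus sabaeus) for cytotoxicity, read by MTT assay, with a stated time of 72 h (on this read-out lower numbers stand for higher toxicity in this test and higher numbers for lower toxicity in this test), and gave only a limit, > 32 ug/mL, not a single number. Compound 1, `C[C@]1(CN2CCc3nc(-c4ccc(OC(F)(F)F)cc4)ccc3C2)Cn2cc([N+](=O)[O-])nc2O1`, has "not determined" (no result reported) in this assay, and compound 2, `C[C@]1(CN2CCc3nc(-c4ccc(Cl)cc4)ccc3C2)Cn2cc([N+](=O)[O-])nc2O1`, likewise has "not determined" (no result reported). The one result in hand is therefore a limit, (the limit of > 32 ug/mL in this assay, at which 1 of the 3 values shown sits). Compound 4, `C[C@]1(CN2CCc3nc(-c4ccc(Cl)c(F)c4)ccc3C2)Cn2cc([N+](=O)[O-])nc2O1`, has not yet been measured; it differs from compound 3 by chloro in place of fluoro on an aromatic carbon. Going by the values given here, no measured pair in this set shows what such a change does to cytotoxicity, so no step beyond the usual scatter is expected in either direction. On that basis compound 4 is expected to give 40 ug/mL, between 16 ug/mL and 100 ug/mL, a step that the limit leaves unreadable from compound 3 to compound 4, most likely again reported only as a limit.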

Compound 4, half-maximal cytotoxic concentration: > 32 ug/mL
Compound 4: only a limit was reported (the forecaster's own chance of this, stated with the estimate: 75%); the middle value lies beyond the limit too.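

Compound 3 and compound 4 each give only a limit, so no step between them can be read: the limit of > 32 ug/mL in this assay, at which 2 of the 4 values shown sit.

The compounds shown leave open whether chloro in place of fluoro shifts the result in this assay at all.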